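Swapping the aryl group on the amine of a tricyclic quinone

The compounds below may be only part of what the source reports. "The series", "measured", "known", "first", "only" and "open" are said of these compounds alone.

Of the compounds shown here, three sharing one core have been measured in a functional assay on HeLa cells (Homo sapiens) for inhibition, read by sulforhodamine B assay; a lower number here means a stronger inhibitor, a higher number a weaker inhibitor. Compound 1 `O=C1C(Nc2cccc(Cl)c2)=CC(=O)c2c1nc1n2[C@H]2OC[C@@H](O)[C@H]2OC1` gives 7970 nM, compound 2 `COc1cccc(NC2=CC(=O)c3nc4n(c3C2=O)[C@H]2OC[C@@H](O)[C@H]2OC4)c1` gives 4280 nM and compound 3 `O=C1C(Nc2ccccc2F)=CC(=O)c2c1nc1n2[C@H]2OC[C@@H](O)[C@H]2OC1` gives 9820 nM. Compound 2 stands lowest of the three, though compound 1 lies within the scatter of it and only compound 3 lies beyond it. The step of a 1.2-fold higher number from compound 1 to compound 3 (0.09 log units; within the scatter) is within the scatter. Compound 4 `O=C1C=C(Nc2ccccc2F)C(=O)c2c1nc1n2[C@H]2OC[C@@H](O)[C@H]2OC1` differs from compound 2 by 2-fluorophenyl in place of 3-methoxyphenyl on an amine nitrogen. Compound 3 already carries the 2-fluorophenyl group, and its value of 9820 nM is the closest guide. Compound 4 is therefore expected to give 9000 nM, within 3500 nM to 25000 nM, an estimated step of a 2.1-fold higher number from compound 2 to compound 4 (0.32 log units; beyond the scatter) at the edge of the scatter.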

Compound 4, half-maximal inhibitory concentration: 5120 nM
The estimate for compound 4 lay 1.8-fold (0.24 log units) above the measured number; measured number inside the range.
By their numbers in this assay, from the lowest: compounds 2, 4, 1 and 3 (each within the scatter of the next, the first and the last beyond it).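

In this assay, the swap gives a 1.2-fold higher number from compound 2 to compound 4 (0.08 log units; within the scatter), so this change on the amine nitrogen leaves the number within the scatter. The aryl group can lose the methoxy oxygen, and with it the hydrogen-bond acceptor counted in 3-methoxyphenyl, without a step beyond the scatter. No measurement here explains this result. From the compounds shown here alone, all four compounds carry a substituted phenyl ring on that nitrogen, so the effect of a pyridine ring or a cyclohexyl group there remains open.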